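This account rests on a few compounds, and the source may have more. Where it says the series, first, only, none or still open, it means among the compounds named here.

Of the compounds shown here, three sharing one core have been measured in a functional assay on MCF7 cells (Homo sapiens) for antiproliferative activity, read by CCK-8 assay, with a stated time of 72 h; a lower number here means a stronger inhibitor, a higher number a weaker inhibitor. Compound 1 `O=C(Nc1cccc(-c2oc3cc(-c4ccc(F)cc4)ccc3c(=O)c2O)c1)c1cccc(F)c1` gives 5770 nM, compound 2 `COc1ccc(C(=O)Nc2cccc(-c3oc4cc(-c5ccc(F)cc5)ccc4c(=O)c3O)c2)c(F)c1` gives 20000 nM, and compound 3 `COc1cc(OC)cc(C(=O)Nc2cccc(-c3oc4cc(-c5ccc(F)cc5)ccc4c(=O)c3O)c2)c1` gives 3470 nM. Compound 3 holds the lowest of the three numbers, although its gap to compound 1 lies within the scatter, so only its separation from compound 2 is firm. Compound 4 `O=C(Nc1cccc(-c2oc3cc(-c4ccc(F)cc4)ccc3c(=O)c2O)c1)c1ccc([N+](=O)[O-])cc1` differs from compound 3 in one place: 4-nitrophenyl in place of 3,5-dimethoxyphenyl on a carbonyl carbon. For the measured compounds named here, the steps that bear on this site are a 1.7-fold lower number from compound 1 to compound 3 (0.22 log units; within the scatter) and a 5.8-fold lower number from compound 2 to compound 3 (0.76 log units; beyond the scatter); exchanging the group on the carbonyl carbon has so far shifted the number modestly, in either direction. A modest step upward is therefore expected, namely a 1.7-fold higher number from compound 3 to compound 4 (0.24 log units; within the scatter). Compound 4 is expected to give 6000 nM, with a range from 2000 nM to 18000 nM.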

Compound 4, half-maximal inhibitory concentration: 3970 nM
Beside the measured number, compound 4's estimate is 1.5-fold (0.18 log units) above it, and the stated range covers the measured number.
By their numbers in this assay, from the lowest: compounds 3, 4 and 1 (each within the scatter of the next); then compound 2.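

Swapping in 4-nitrophenyl gives a 1.1-fold higher number from compound 3 to compound 4 (0.06 log units; within the scatter) and a 1.5-fold lower number from compound 1 to compound 4 (0.16 log units; within the scatter), so this place on the carbonyl carbon holds 3,5-dimethoxyphenyl, 3-fluorophenyl and 4-nitrophenyl at one level despite their different substituents. Compound 2 alone stands apart, since a 5.0-fold lower number from compound 2 to compound 4 (0.70 log units; beyond the scatter) shows that its 2-fluoro-4-methoxyphenyl group is the exception here. No measurement shown gives a reason for this pattern. Every group shown at this place is a substituted phenyl ring, so it stays open how an amine, a carboxylic acid or a longer chain would behave.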